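The compounds below may be only part of what the source reports. "The series", "measured", "known", "first", "only" and "open" are said of these compounds alone.

Working notes on the series. Compound 1 `C=C1C(=O)[C@]23C[C@@]1(O)CC[C@H]2c1ccc(O)c(C)c1[C@@H]3Cn1cc(-c2ccccn2)nn1` and compound 2 `C=C1C(=O)[C@]23C[C@@]1(O)CC[C@H]2c1ccc(O)c(C)c1[C@@H]3Cn1cc(-c2ccc(C(F)(F)F)cc2)nn1` share one core; compound 3 `C=C1C[C@]23C[C@@]1(O)CC[C@H]2c1ccc(OS(=O)(=O)c2ccc(C)cc2)c(C)c1[C@@H]3Cn1cc(-c2ccc(C(F)(F)F)cc2)nn1` and compound 4 `C=C1C[C@]23C[C@@]1(O)CC[C@H]2c1ccc(OS(=O)(=O)c2ccc(C)cc2)c(C)c1[C@@H]3Cn1cc(-c2ccccn2)nn1` share another, and the difference between the two cores is not broken down here. In a functional assay on A549 cells (Homo sapiens) for cytotoxicity, read by MTT assay, with a stated time of 4 days (on this read-out higher numbers stand for weaker inhibition and lower numbers for stronger inhibition), compound 2 gives 1110 nM. In this assay compound 1 gives 1570 nM. The change pyridin-2-yl in place of 4-(trifluoromethyl)phenyl on an aromatic carbon thus gave a 1.4-fold higher number from compound 2 to compound 1 (0.15 log units; within the scatter). For compound 3 this assay reports only a limit, > 20000 nM; this is the limit of > 20000 nM in this assay, at which 1 of the 3 values shown sits. The same kind of change, (pyridin-2-yl in place of 4-(trifluoromethyl)phenyl on an aromatic carbon), carries compound 3 to compound 4, which is not yet measured. Because a 1.4-fold higher number from compound 2 to compound 1 (0.15 log units; within the scatter) stayed within the scatter, the step that the limit leaves unreadable from compound 3 to compound 4 is expected to be small as well, and compound 4 is expected to stand at about 25000 nM in this assay, with 8000 nM to 80000 nM as the likely range, most probably again as a limit.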

Compound 4, half-maximal inhibitory concentration: > 20000 nM
Compound 4: only a limit was reported; the forecaster's own chance of this, stated with the estimate: 75%; the middle value does not contradict the limit.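

In this assay compound 3 and compound 4 are both reported only as limits, so no step can be read between them: the limit of > 20000 nM in this assay, at which 2 of the 4 values shown sit.

The compounds shown leave open what pyridin-2-yl in place of 4-(trifluoromethyl)phenyl does on the core of compound 3.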